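The source may report more compounds than this note shows. Statements on the series, on what has been measured and on what is new or still open speak of the compounds shown alone.

Compound 1 `Cc1oc(-c2ccc(Cl)cc2)nc1CN1CCC(C(=O)NCCCN2C[C@H](C)C[C@H](C)C2)CC1` gives > 72 ug/mL in a physicochemical assay for solubility, in phosphate buffer, measured as kinetic solubility, at pH 7.4; a lower number here means a less soluble compound, a higher number a more soluble compound.
Compound 2 `Cc1ccccc1-c1nc(CN2CCC(C(=O)NCCCN3CC4CCCC(C4)C3)CC2)c(C)o1` gives > 71 ug/mL in this assay.
Compound 3 `Cc1cccc(Cl)c1-c1nc(CN2CCC(C(=O)NCCCN3CCC(C)(C)CC3)CC2)c(C)o1` gives > 74 ug/mL in this assay.

Each of these values is a limit of this assay, not a number. Compound 1 stands at the limit of > 72 ug/mL in this assay, at which 1 of the 3 values shown sits. For the measured compounds named here, no step between two measured compounds is given here, so all that can be said is that the three compounds each sit at a limit. Compound 4 `Cc1cc(C)cc(-c2nc(CN3CCC(C(=O)NCCCN4C[C@H](C)C[C@H](C)C4)CC3)c(C)o2)c1` has not yet been measured in this assay. It differs from compound 1 in one place: 3,5-dimethylphenyl in place of 4-chlorophenyl on an aromatic carbon. Going by the values given here, with no measured step to lean on, the expected step that the limit leaves unreadable from compound 1 to compound 4 is none beyond the usual scatter. Compound 4 is therefore expected to give about 75 ug/mL in this assay, within 35 ug/mL to 150 ug/mL, most likely reported once more as a limit rather than a number.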

Compound 4, solubility: > 71 ug/mL
Compound 4: a limit, no number; the forecaster's own chance of this, stated with the estimate: 75%; the middle value does not contradict the limit.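

For the compounds shown here, compound 1 and compound 4 are both reported only as limits in this assay, so no step between them can be read. As far as these compounds go, what stays open is the actual number behind each of the four limits, and whether 3,5-dimethylphenyl in place of 4-chlorophenyl changes anything in this assay.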